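This account rests on a few compounds, and the source may have more. Where it says the series, first, only, none or still open, it means among the compounds named here.

Measured compounds:
- compound 1 `CC(C)CSc1n[nH]c(-n2[se]c3ccccc3c2=O)n1`: 33400 nM in an ADME assay on L929 cells (Mus musculus) for antiproliferative activity, read by CCK-8 assay, with a stated time of 48 h; on this read-out lower numbers stand for stronger inhibition and higher numbers for weaker inhibition
- compound 2 `O=c1c2ccccc2[se]n1-c1nc(SCc2ccc(F)cc2)n[nH]1`: > 50000 nM in this assay

Compound 2 stands at the weak end of the two values shown. In this assay compound 2 gives > 50000 nM, which is a limit of the assay and not a number. Within the pair, compound 1 sits below that limit, with the step of an at least 1.4-fold higher number from compound 1 to compound 2 (0.17 log units; that floor lies within the scatter); the only evidence on this step is the limit of > 50000 nM in this assay, at which 1 of the 2 values shown sits.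

Compound 3 `CC(C)Sc1n[nH]c(-n2[se]c3ccccc3c2=O)n1` is not yet measured. It differs from compound 2 by isopropyl in place of 4-fluorobenzyl on a sulfur. For the measured compounds named here, the one measured step that bears on it is the step from compound 1 to compound 2, which runs the other way around a closely related change, and its floor lies within the scatter. The step of an at least 1.4-fold lower number from compound 2 to compound 3 (0.15 log units; that floor lies within the scatter) is therefore expected to bring the number back down toward compound 1, with no strong grounds for a step clearly beyond the scatter. Compound 3 is estimated at 35000 nM, with a range from 12000 nM to 100000 nM.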

Compound 3, half-maximal inhibitory concentration: 37100 nM
Beside the measured number, compound 3's estimate is 1.1-fold (0.03 log units) below it; the measured number falls inside the stated range.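

On the sulfur whose other neighbour is an aromatic carbon, isopropyl in place of isobutyl gives a 1.1-fold higher number from compound 1 to compound 3 (0.05 log units; within the scatter) in this assay, so these two groups cannot be told apart on this read-out. Isopropyl in place of 4-fluorobenzyl gives an at least 1.3-fold lower number from compound 2 to compound 3 (0.12 log units; that floor lies within the scatter), so even with the ring-bearing group exchanged, the floor of the step does not clear the scatter. For compound 2 the reading is a limit of the assay and not a number: the limit of > 50000 nM in this assay, at which 1 of the 3 values shown sits.

On these data alone, how far 4-fluorobenzyl truly lies from isopropyl stays open, as only a limit stands for compound 2. Also open, as far as these compounds go, is how a longer chain, an amine or a carboxylic acid on this sulfur would read in this assay.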